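Trimming the amide ethyl to methyl in compound 2

The source may report more compounds than this note shows. Statements on the series, on what has been measured and on what is new or still open speak of the compounds shown alone.

Of the compounds shown here, three have been measured in an assay on the whole organism (plasma, strain Sprague-Dawley) for inhibition of Dipeptidyl peptidase 4 (Rattus norvegicus), with a stated time of 6 h, at a dose of 1 mg/kg by the oral route; on this read-out lower numbers stand for less inhibition and higher numbers for more inhibition at the one dose given (going by the name of the read-out). Compound 1 `N#C[C@@H]1CCCN1C(=O)[C@@H]1C[C@H](CO)CN1` gives 64%. Compound 3 `CCN(C)C(=O)[C@@H]1CN[C@H](C(=O)N2CCC[C@H]2C#N)C1` gives 71%, and a number 7 percentage points higher from compound 1 to compound 3 (within the scatter) shows that ethyl(methyl)carbamoyl in place of hydroxymethyl on a saturated ring carbon hardly moves the read-out. Compound 2 `CCN(C)C(=O)[C@H]1C[C@@H](C(=O)N2CCC[C@H]2C#N)N[C@H]1C` gives 92%, the highest of the three numbers; its steps to compound 3 and to compound 1 both lie beyond the scatter, and a number 21 percentage points lower from compound 2 to compound 3 (beyond the scatter) shows the drop that goes with hydrogen in place of methyl on a saturated ring carbon.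

Compound 4 `C[C@@H]1N[C@H](C(=O)N2CCC[C@H]2C#N)C[C@@H]1C(=O)N(C)C` has not yet been measured. It differs from compound 2 by hydrogen in place of methyl on a saturated chain carbon bound to an amide-type nitrogen, so the change sits in the ethyl(methyl)carbamoyl group rather than on the ring. Going by the values given here, no measured step alters this group in the same way; the nearest is the step from compound 1 to compound 3, which brought in the whole ethyl(methyl)carbamoyl group and stayed within the scatter. Among the compounds with values here, with no step to build on, the expectation for compound 4 is a read-out close to that of compound 2, with a number 5 percentage points lower from compound 2 to compound 4 (within the scatter) expected to stay within the scatter. The estimate for compound 4 is 87%, ranging from 70% to 96%.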

Compound 4, a percentage reported as inhibition, in the whole organism at one dose (the size of the read-out at that dose, not a potency): 95%
Estimate against measurement, compound 4: 8 percentage points below; low and high end bracket the measured number.
By their numbers in this assay, from the lowest: compounds 1 and 3 (each within the scatter of the next); then compounds 2 and 4 (each within the scatter of the next).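

In this assay, the step of a number 3 percentage points higher from compound 2 to compound 4 (within the scatter) shows that hydrogen in place of methyl on a saturated chain carbon bound to an amide-type nitrogen, which turns ethyl(methyl)carbamoyl into dimethylcarbamoyl, leaves the read-out within the scatter, so the ethyl of the amide can be trimmed to methyl without a measurable change at this dose and time. The earlier compounds had shown this amide group only as a whole, and the one earlier exchange of methyl for hydrogen, on a saturated ring carbon, gave a step beyond the scatter, a number 21 percentage points lower from compound 2 to compound 3 (beyond the scatter), so the same exchange reads differently at the two places in this small set. Nothing available explains this difference between the two places.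

With compound 2 at 92% and compound 4 at 95%, a single dose and a single time leave open whether the two would separate at a lower dose or a later time. Also open, going by these compounds, is how a longer chain such as propyl on the amide nitrogen, or a carboxylic acid in place of the whole amide, would read in this assay.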